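This account rests on a few compounds, and the source may have more. Where it says the series, first, only, none or still open, it means among the compounds named here.

compound 1 `O=C1C=CC[C@H](c2cccc3ccccc23)O1`: 2600 nM
compound 2 `Cc1ccc2ccccc2c1[C@H]1CC=CC(=O)O1`: 2600 nM
compound 3 `Cc1ccc([C@H]2CC=CC(=O)O2)c2ccccc12`: not yet measured

Among the measured compounds shown here, in a functional assay on MCF7 cells (Homo sapiens) for cytotoxicity, read by MTT assay, with a stated time of 48 h (a lower number here means a stronger inhibitor, a higher number a weaker inhibitor), compound 1 gives 2600 nM and stands level with compound 2 at 2600 nM as the only other measured compound. Compound 3 differs from compound 1 by methyl in place of hydrogen on an aromatic carbon on the shared core, which is methyl in place of hydrogen on an aromatic carbon. For the measured compounds named here, one measured step bears on this change. The step of no change at the digits printed from compound 1 to compound 2 (within the scatter) is the same kind of replacement on a different aromatic carbon, and it stays within the scatter. Going by the values given here, it is the only such step, so no measurement yet shows what a methyl does at the place it takes in compound 3, and the evidence is thin. A shift beyond the scatter is not expected in this assay because no change at the digits printed from compound 1 to compound 2 (within the scatter) gave none, and no direction is favoured. The expected step is no change at the digits printed from compound 1 to compound 3 (within the scatter) on this single precedent. For compound 3 the estimated value is 2600 nM with an expected range from 1000 nM to 6500 nM in this assay at this stage.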

Compound 3, half-maximal inhibitory concentration: 440 nM
Compound 3: the middle estimate sits 5.9-fold (0.77 log units) above what was measured; the measured number lies below the stated range.
By their numbers in this assay, from the lowest: compound 3; then compounds 1 and 2 (each within the scatter of the next).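

In this assay, methyl in place of hydrogen on the aromatic carbon para to a group of 7 heavy atoms gives a 5.9-fold lower number from compound 1 to compound 3 (0.77 log units; beyond the scatter) while the same replacement on a different aromatic carbon gave no change at the digits printed from compound 1 to compound 2 (within the scatter) and stayed within the scatter. Among these three compounds, the outcome of this one-atom replacement therefore depends on which aromatic carbon carries the methyl, and the carbon in compound 3 is the first place on the shared core where the replacement moves the number beyond the scatter. Nothing measured here accounts for the difference between the two carbons.

On these data alone, it remains open whether the lower number is specific to methyl at this carbon or would also appear with an ethyl, a methoxy, a chlorine, an amine or a carboxylic acid in the same place. Also open, as far as these compounds go, are what a methyl does on the remaining aromatic carbons, and whether methyl groups on both carbons together would give a number different from that of compound 3 with its single methyl.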